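The compounds below may be only part of what the source reports. "The series", "measured", "known", "first", "only" and "open" are said of these compounds alone.

Of the compounds shown here, two sharing one core have been measured so far in a functional assay on ECV-304 cells (Homo sapiens) for cytotoxicity; a higher number here means a weaker inhibitor, a lower number a stronger inhibitor. Compound 1 `COc1cccc(/C=C2\SC(=S)N(NS(=O)(=O)c3ccccc3)C2=O)c1` gives only a limit, > 50000 nM. Compound 2 `O=C1/C(=C/c2ccccc2F)SC(=S)N1NS(=O)(=O)c1ccccc1` also gives only a limit, > 50000 nM. That leaves compound 2 with no readable number, and the record so far is the limit of > 50000 nM in this assay, at which 2 of the 2 values shown sit.

Compound 3 `O=C1/C(=C/c2ccc(Cl)c(Cl)c2)SC(=S)N1NS(=O)(=O)c1ccccc1` keeps the shared core and changes the aryl group of compound 2: 3,4-dichlorophenyl in place of 2-fluorophenyl on a double-bonded chain carbon bound to a double-bonded ring carbon. For the measured compounds named here, the one measured exchange at this place is a step that the two limits leave unreadable from compound 1 to compound 2. Going by the values given here, it is the only step that bears on the new change, and it supplies no size to carry over. Nothing measured in this assay therefore points to a step of any particular size or direction, and the most reasonable expectation is that compound 3 stays close to the same limit. The expected change, a number no higher from compound 2 to compound 3 (the limit leaves the size open), is only an estimate and has no firm direction. For compound 3 the estimated half-maximal inhibitory concentration is 50000 nM, with an expected range from 20000 nM to 100000 nM.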

Compound 3, half-maximal inhibitory concentration: > 50000 nM
Compound 3 was reported as a limit (the forecaster's own chance of this, stated with the estimate: 70%); the middle value lies on the limit itself.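

Compound 3 joins compound 1 and compound 2 in giving only a limit in this assay, so no step among the three can be read: the limit of > 50000 nM in this assay, at which 3 of the 3 values shown sit.

The compounds shown leave open how strongly any of the three inhibits in this assay, and whether any aryl group at this place can give a readable value.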